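Aryl change on the aromatic nitrogen: compound 3 to compound 4

A few compounds are considered here, and "the series" means these few. Any claim that something is new, unique, unknown or untested is made for them only; others in the source may bear on it.

The three measured compounds share one core and differ only in the aryl group on an aromatic nitrogen. Compound 1 `CCc1ccccc1-n1nncc1CN1C(=O)C2(C(C#N)=C(N)Oc3c(N)cc4nc5ccccc5nc4c32)c2ccccc21` carries 2-ethylphenyl there; in a functional assay on A549 cells (Homo sapiens) for antiproliferative activity, read by MTT assay, with a stated time of 48 h (on this read-out lower numbers stand for stronger inhibition and higher numbers for weaker inhibition), compound 1 gives 24600 nM. Compound 2 `CCOc1ccc(-n2nncc2CN2C(=O)C3(C(C#N)=C(N)Oc4c(N)cc5nc6ccccc6nc5c43)c3ccccc32)cc1` carries 4-ethoxyphenyl, and in this assay compound 2 reaches only the limit > 50000 nM. Compound 3 `Cc1ccc(Cl)cc1-n1nncc1CN1C(=O)C2(C(C#N)=C(N)Oc3c(N)cc4nc5ccccc5nc4c32)c2ccccc21` carries 5-chloro-2-methylphenyl, and in this assay compound 3 likewise gives only the limit > 50000 nM. Compound 3 therefore stands at the upper boundary of what the assay reports: the step of an at least 2.0-fold higher number from compound 1 to compound 3 (0.30 log units; that floor lies within the scatter) is bounded from one side only, and the step that the two limits leave unreadable from compound 2 to compound 3 cannot be read, both values sitting at the same boundary (the limit of > 50000 nM in this assay, at which 2 of the 3 values shown sit).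

Compound 4 `COc1cc(-n2nncc2CN2C(=O)C3(C(C#N)=C(N)Oc4c(N)cc5nc6ccccc6nc5c43)c3ccccc32)c(OC)cc1Cl` differs from compound 3 by 4-chloro-2,5-dimethoxyphenyl in place of 5-chloro-2-methylphenyl on an aromatic nitrogen. For the measured compounds named here, the steps that bear on this change are an at least 2.0-fold higher number from compound 1 to compound 2 (0.30 log units; that floor lies within the scatter) and an at least 2.0-fold higher number from compound 1 to compound 3 (0.30 log units; that floor lies within the scatter): each aryl change away from 2-ethylphenyl gave a number at the limit, and no measured step starts from a numbered value at compound 3. The expected step is accordingly a number no higher from compound 3 to compound 4 (the limit leaves the size open), with compound 4 most likely again reported only as a limit. Compound 4 is estimated at 50000 nM, in a range from 20000 nM to 150000 nM.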

Compound 4, half-maximal inhibitory concentration: > 50000 nM
Compound 4 was reported as a limit (the forecaster's own chance of this, stated with the estimate: 70%); the middle value lies on the limit itself.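

In this assay compound 4 gives > 50000 nM, which is a limit and not a number. The change to 4-chloro-2,5-dimethoxyphenyl gives an at least 2.0-fold higher number from compound 1 to compound 4 (0.30 log units; that floor lies within the scatter), so this is a third aryl change from 2-ethylphenyl that is bounded from one side only, and it now includes a group with 2 hydrogen-bond acceptors where 5-chloro-2-methylphenyl has 0. The steps among compound 2, compound 3 and compound 4 cannot be read, so no order among these aryl groups can be drawn, and the result adds to the values held at one boundary: the limit of > 50000 nM in this assay, at which 3 of the 4 values shown sit.

For the compounds shown here, whether compound 2, compound 3 and compound 4 differ at all in this assay stays open, as does whether compound 1 keeps the only numbered value among aryl groups at this position. Also open, as far as these compounds go, is how an aryl group on this aromatic nitrogen would read with an amine or a carboxylic acid on the ring, or with a propyl chain in place of the ethyl of 2-ethylphenyl.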